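The source may hold more compounds than are shown below. What is called first, only, known or untested is meant among the compounds shown, and "the series" means these compounds.

Two compounds of the series carry numbers in a functional assay on PC-3 cells (Homo sapiens) for antiproliferative activity, read by sulforhodamine B assay, with a stated time of 48 h (on this read-out higher numbers stand for weaker inhibition of growth and lower numbers for stronger inhibition of growth), so far. Compound 1 `COc1ccc(OC)c(/C=C/c2nnc(Nc3ccc(Cl)cc3)o2)c1` gives 13300 nM, and compound 2 `COc1ccc(OC)c(/C=C/C(=O)N/N=C/c2ccc(Cl)cc2)c1` gives 169 nM. Compound 2 therefore holds the lower of the two numbers, and its gap to compound 1 lies well beyond the scatter, so of this pair compound 2 is the stronger inhibitor of growth. Going by the values given here, no two measured compounds differ in a single place, so no single-point step is available to lean on.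

Compound 3 `COc1ccc(OC)c(/C=C/C(=O)N/N=C/c2ccccc2)c1` has not been measured. It differs from compound 2 by hydrogen in place of chloro on an aromatic carbon; cut one bond further out, the difference reads 4-chlorophenyl to phenyl. Nothing in the measured set shows what this exchange does on the core of compound 2, and compound 1 offers no guide, since it differs from compound 2 in more than one place.

On the strength of compound 2 alone, the change is expected to cost a moderate amount of potency, giving a step of a 2.4-fold higher number from compound 2 to compound 3 (0.37 log units; beyond the scatter), probably just beyond the scatter. For compound 3 the estimated value is 400 nM, with an expected range from 150 nM to 1200 nM.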

Compound 3, concentration for 50% growth inhibition: 5860 nM
Compound 3: the middle estimate sits 15-fold (1.17 log units) below what was measured; measured number above the stated range.
By their numbers in this assay, from the lowest: compound 2; then compound 3; then compound 1.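

In this assay the series now has its first single-place step: a 35-fold higher number from compound 2 to compound 3 (1.54 log units; beyond the scatter) is large, so at this position, on an aromatic carbon para to a large group, the exchange of chloro for hydrogen is far from neutral. The loss of one heavy atom is enough to move the number well beyond the scatter, which shows that on this core the low number of compound 2 depends on the chloro group and is not held by the rest of the structure alone. The data in hand offer no measurement that explains why this single exchange has so large a step.

Still open, on these data alone, is whether other groups at this position, such as fluoro, bromo, methyl, methoxy or an amine, would keep the number of compound 2 or fall towards that of compound 3, which would tell whether chloro itself is needed or whether any replacement for hydrogen serves. Also open, as far as these compounds go, is whether the same 4-chlorophenyl to phenyl exchange on the core of compound 1 would give a step of similar size, so the result stands for the core of compound 2 only.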